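A benzylcarbamoyl group replaces butylsulfonyl on the shared core

The source may report more compounds than this note shows. Statements on the series, on what has been measured and on what is new or still open speak of the compounds shown alone.

Measured so far in a functional assay for binding affinity, with Homo sapiens as the target, read by fluorescence and flow cytometry (a lower number here means tighter binding, a higher number weaker binding), are two compounds:
compound 1 `O=C(NC[C@H](NS(=O)(=O)c1cccs1)C(=O)O)c1cc2sc(CCC3CCNCC3)cc2s1` gives 0.092 nM
compound 2 `CCCCS(=O)(=O)N[C@@H](CNC(=O)c1cc2sc(CCC3CCNCC3)cc2s1)C(=O)O` gives 3 nM

Of these two, compound 2 has the higher number and so the weaker binding. Compound 3 `O=C(NCc1ccccc1)N[C@@H](CNC(=O)c1cc2sc(CCC3CCNCC3)cc2s1)C(=O)O` differs from it by benzylcarbamoyl in place of butylsulfonyl on an amine nitrogen with benzylcarbamoyl in place of butylsulfonyl on an amine nitrogen. Among the measured compounds shown here, the only measured step bearing on this is the large 33-fold higher number from compound 1 to compound 2 (1.51 log units; beyond the scatter) for butyl in place of thiophen-2-yl on a sulfonyl sulfur. That step shows that this part of the structure can move the number considerably, but it does not cover the loss of the sulfonyl group, and so it gives no direction. The expected step, an estimate only, is a 1.5-fold lower number from compound 2 to compound 3 (0.18 log units; within the scatter) and may well stay within the scatter. Compound 3 is expected at 2 nM with an estimated range from 0.3 nM to 15 nM in this assay once measured.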

Compound 3, dissociation constant: 33 nM
Estimate against measurement, compound 3: 17-fold (1.22 log units) below; the measured number lies above the stated range.
By their numbers in this assay, from the lowest: compound 1; then compound 2; then compound 3.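

In this assay benzylcarbamoyl in place of butylsulfonyl on this amine nitrogen gives an 11-fold higher number from compound 2 to compound 3 (1.04 log units; beyond the scatter) and in place of (thiophen-2-yl)sulfonyl gives a 360-fold higher number from compound 1 to compound 3 (2.55 log units; beyond the scatter) in the same direction. The earlier pair varied only the group on the sulfonyl sulfur, whereas these steps show that replacing the whole sulfonyl unit also weakens binding, leaving compound 3 the weakest binder of the three. Nothing given here accounts for this change.

Still open, going by these compounds, is whether the loss follows the carbonyl in place of the sulfonyl or the benzyl group. Benzylsulfonyl and butylcarbamoyl on the same nitrogen would separate the two.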